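The source may hold more compounds than are shown below. What is called first, only, known or untested is meant among the compounds shown, and "the series" means these compounds.

Of the compounds shown here, two with a shared core have been measured in a functional assay on the whole organism (strain Kunming) with Mus musculus as the target, in the formalin test, with a stated time of 0.5 h; a lower number here means that less compound is needed, a higher number that more compound is needed for the effect. Compound 1 (`COc1ccccc1/C=C/C(=O)OC/C=C/c1cc(OC)c(OC)cc1OC`) gives 113 mg/kg, and compound 2 (`COc1cc(OC)c(OC)cc1/C=C/COC(=O)/C=C/c1ccc(Br)cc1`) gives 105 mg/kg. Compound 2 thus stands within the scatter of compound 1, and the two numbers cannot be ranked. The unmeasured compound 3 (`COc1cc(OC)c(OC)cc1/C=C/COC(=O)/C=C/c1ccccc1C(F)(F)F`) carries 2-(trifluoromethyl)phenyl in place of 4-bromophenyl on a double-bonded chain carbon bound to a double-bonded chain carbon. For the measured compounds named here, only one measured step bears on this change, a 1.1-fold lower number from compound 1 to compound 2 (0.03 log units; within the scatter), where 4-bromophenyl replaced 2-methoxyphenyl at that same place. Going by the values given here, no measured compound carries 2-(trifluoromethyl)phenyl, so this single step is indirect evidence. Nothing beyond the scatter is therefore expected in this assay, and no direction is favoured. The expected change is a 1.0-fold higher number from compound 2 to compound 3 (0.01 log units; within the scatter). Compound 3 is estimated at 108 mg/kg, with an expected range of 60 mg/kg to 190 mg/kg.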

Compound 3, dose for half-maximal effect: 123 mg/kg
The estimate for compound 3 lay 1.1-fold (0.06 log units) below the measured number; low and high end bracket the measured number.
By their numbers in this assay, from the lowest: compounds 2, 1 and 3 (each within the scatter of the next).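

In this assay, 2-(trifluoromethyl)phenyl in place of 4-bromophenyl on a double-bonded chain carbon bound to a double-bonded chain carbon gives a 1.2-fold higher number from compound 2 to compound 3 (0.07 log units; within the scatter) and so adds a third substituted phenyl group at this place whose number cannot be ranked against the others. Trifluoromethyl in place of methoxy on an aromatic carbon gives a 1.1-fold higher number from compound 1 to compound 3 (0.04 log units; within the scatter) and shows that this exchange also leaves the three compounds unseparated in this test. No independent measurement bears on these results.

The compounds shown leave open whether any group at this place can move the number beyond the scatter, since all three carry a substituted phenyl group. A phenyl group bearing an amine or a carboxylic acid, or a saturated alkyl chain in place of the phenyl group, would test this.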